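Changing the carbonyl substituent of compound 2

This account rests on a few compounds, and the source may have more. Where it says the series, first, only, none or still open, it means among the compounds named here.

Of the compounds shown here, two sharing a core have been measured in a functional assay on Shh Light II cells (Mus musculus) for inhibition, read by a luciferase reporter; a lower number here means a stronger inhibitor, a higher number a weaker inhibitor. Compound 1 (`O=C(NC1CCC(O)CC1)N1CCC(c2nc(-c3ccc4ccccc4n3)no2)CC1`) gives 2700 nM, and compound 2 (`O=C(OC1CCCCC1)N1CCC(c2nc(-c3ccc4ccccc4n3)no2)CC1`) gives 580 nM, the lower of the two numbers. Compound 3 (`N#Cc1ccccc1NC(=O)N1CCC(c2nc(-c3ccc4ccccc4n3)no2)CC1`) has (2-cyanophenyl)amino in place of cyclohexyloxy on a carbonyl carbon. Among the measured compounds shown here, the one measured step that bears on this is a 4.7-fold lower number from compound 1 to compound 2 (0.67 log units; beyond the scatter), a modest change, with cyclohexyloxy replacing (4-hydroxycyclohexyl)amino at that carbon. Compound 3 again has an amino group there, but with an aromatic ring, so little guidance exists on direction. The expected step is small: a 1.2-fold higher number from compound 2 to compound 3 (0.08 log units; within the scatter). The estimate for compound 3 is 700 nM, with an expected range of 150 nM to 3000 nM.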

Compound 3, half-maximal inhibitory concentration: 190 nM
Compound 3: middle estimate off by 3.7-fold (0.57 log units), on the high side; the range from low to high includes it.
By their numbers in this assay, from the lowest: compound 3; then compound 2; then compound 1.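

In this assay, the group on the amino nitrogen at this carbonyl carbon matters greatly: 2-cyanophenyl replacing 4-hydroxycyclohexyl gives a 14-fold lower number from compound 1 to compound 3 (1.15 log units; beyond the scatter). An amino link here therefore does not by itself give a weaker inhibitor, since (2-cyanophenyl)amino replacing cyclohexyloxy gives a 3.1-fold lower number from compound 2 to compound 3 (0.48 log units; beyond the scatter). Nothing available explains these gains.

The compounds shown leave open whether the nitrile or the aromatic ring accounts for the gain. An unsubstituted phenyl on the same nitrogen would separate the two, and a plain cyclohexyl there would show what the hydroxyl of compound 1 contributes.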